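Solubility of a Nitrophenyl for Dichlorophenyl Swap

The source may report more compounds than this note shows. Statements on the series, on what has been measured and on what is new or still open speak of the compounds shown alone.

Of the compounds shown here, three sharing a related core have been measured in a physicochemical assay for solubility, in phosphate buffer, at pH 7.4; on this read-out higher numbers stand for higher solubility and lower numbers for lower solubility. Compound 1 `CCOC(=O)c1c(-c2cccc([N+](=O)[O-])c2)[nH]c2cc(OC)ccc2c1=O` gives 13000 nM. Compound 2 `CCOC(=O)c1c(-c2ccc(Cl)c(Cl)c2)[nH]c2cc(OC)ccc2c1=O` gives 17000 nM. Compound 3 `CCOC(=O)c1c(-c2ccc(Cl)c(Cl)c2)[nH]c2cccc(OC)c2c1=O` gives 39000 nM, the highest of the three. The core of compound 3 differs from that of compound 2 in how the same atoms are joined; that difference between the two cores is not broken down here.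

Compound 1 differs from compound 2 by one change, (3-nitrophenyl in place of 3,4-dichlorophenyl on an aromatic carbon), and the step was a 1.3-fold lower number from compound 2 to compound 1 (0.12 log units; within the scatter).

Compound 4 `CCOC(=O)c1c(-c2cccc([N+](=O)[O-])c2)[nH]c2cccc(OC)c2c1=O` has not yet been measured in this assay. It differs from compound 3 by the same change, (3-nitrophenyl in place of 3,4-dichlorophenyl on an aromatic carbon). Because the earlier step of a 1.3-fold lower number from compound 2 to compound 1 (0.12 log units; within the scatter) stayed within the scatter, the step from compound 3 to compound 4 is expected to be similar in size, roughly a 1.3-fold lower number from compound 3 to compound 4 (0.11 log units; within the scatter). On that basis compound 4 is estimated at about 30000 nM, with a plausible range from 15000 nM to 60000 nM.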

Compound 4, solubility: 49000 nM
The estimate for compound 4 lay 1.6-fold (0.21 log units) below the measured number; low and high end bracket the measured number.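

In this assay, putting 3-nitrophenyl in place of 3,4-dichlorophenyl gives a 1.3-fold higher number from compound 3 to compound 4 (0.10 log units; within the scatter) on one core, and the same change gave a 1.3-fold lower number from compound 2 to compound 1 (0.12 log units; within the scatter) on the other. For these two pairs, then, the change carried over from one core to the other without a step large enough to read, and neither step can be given a reliable direction. Two pairs do not show that the change would stay this small on any other core, and nothing measured here accounts for the result.

Left open is how a phenyl ring carrying an amine or a morpholine would behave in the same place, on the aromatic carbon next to the ring nitrogen, on either core. Also open, going by these compounds, is whether the step would stay this small if a carboxylic acid stood in place of the ethoxycarbonyl group.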